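The compounds below may be only part of what the source reports. "The series", "measured", "known", "first", "only" and "open" are said of these compounds alone.

The measured compounds:
Compound 1 `O=C(NO)c1ccc(-c2cn([C@@H]3C[C@H](C(=O)O)N(Cc4ccccc4)C3)nn2)cc1` gives < 10% in an assay on Sf9 cells for inhibition of histone deacetylase 11 (Homo sapiens), read by fluorescence, tested at 0.5 uM (a lower number here means less inhibition, a higher number more inhibition at the concentration tested (going by the name of the read-out)), a limit of the assay rather than a number.
Compound 2 `O=C(NO)c1cccc(-c2cn([C@H]3C[C@H](C(=O)O)N(Cc4ccccc4)C3)nn2)c1` gives < 10% in this assay, again a limit.
Compound 3 `O=C(/C=C/c1cn([C@H]2C[C@H](C(=O)O)N(Cc3ccccc3)C2)nn1)NO` gives 14% in this assay.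

Within the data shown here, compound 3 thus holds the only number among the three values; the other two sit at the limit of < 10% in this assay, at which 2 of the 3 values shown sit. Compound 4 `O=C(NO)c1ccc(-c2cn([C@H]3C[C@H](C(=O)O)N(Cc4ccccc4)C3)nn2)cc1` carries 4-(hydroxycarbamoyl)phenyl in place of 2-(hydroxycarbamoyl)ethenyl on an aromatic carbon. Among the measured compounds shown here, the single measured step that bears on this change runs the other way, a number at least 4 percentage points higher from compound 2 to compound 3 (that floor lies within the scatter), where the ethenyl arm entered in place of a 3-(hydroxycarbamoyl)phenyl; its floor lies within the scatter. Compound 1 also bears the 4-(hydroxycarbamoyl)phenyl arm that enters here. Reversing the direction, compound 4 is expected to give 9%, within 3% to 16%. The expected step of a number 5 percentage points lower from compound 3 to compound 4 (within the scatter) stays within the scatter, and compound 4 may well be reported only as a limit.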

Compound 4, a percentage reported as inhibition, at one concentration (the size of the read-out at that concentration, not a potency): < 10%
Compound 4: only a limit was reported (the forecaster's own chance of this, stated with the estimate: 60%); the middle value lies beyond the limit too.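

In this assay, exchanging the arm on this aromatic carbon gives a number at least 4 percentage points lower from compound 3 to compound 4 (that floor lies within the scatter), so the 4-(hydroxycarbamoyl)phenyl arm is not shown to differ from the 2-(hydroxycarbamoyl)ethenyl arm. The steps to compound 4 from compound 1 and from compound 2 cannot be read, with both ends of each step at a limit: the limit of < 10% in this assay, at which 3 of the 4 values shown sit. The comparison of configuration therefore yields no size either: the fact that compounds 1 and 4 differ only in the configuration as drawn.

As far as these compounds go, it remains open whether a longer chain in place of this arm would raise the read-out beyond the scatter. From the compounds shown here alone, the effect of an amine in place of the carboxylic acid is also open.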